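The source may report more compounds than this note shows. Statements on the series, on what has been measured and on what is new or still open speak of the compounds shown alone.

Three compounds share one core and differ only in the aryl group on the amide-type nitrogen. Compound 1 `COc1ccc(NC(=O)Nc2cccc(CNc3nccnc3Cl)c2)cc1` carries a 4-methoxyphenyl there, and in a functional assay on T-24 cells (Homo sapiens) for antiproliferative activity, read by MTT assay, with a stated time of 48 h (on this read-out lower numbers stand for stronger inhibition and higher numbers for weaker inhibition), compound 1 gives 9820 nM. Compound 2 `CN(C)c1ccc(NC(=O)Nc2cccc(CNc3nccnc3Cl)c2)cc1` carries a 4-(dimethylamino)phenyl, and in this assay compound 2 gives 20200 nM. Compound 3 `O=C(Nc1cccc(CNc2nccnc2Cl)c1)Nc1ccccc1F` carries a 2-fluorophenyl, and in this assay compound 3 gives 7450 nM, the lowest of the three numbers. The steps toward it are a 1.3-fold lower number from compound 1 to compound 3 (0.12 log units; within the scatter) and a 2.7-fold lower number from compound 2 to compound 3 (0.43 log units; beyond the scatter), while the other two are separated by a 2.1-fold higher number from compound 1 to compound 2 (0.31 log units; beyond the scatter).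

Compound 4 `O=C(Nc1cccc(CNc2nccnc2Cl)c1)Nc1ccccc1Cl` differs from compound 3 in one place: chloro in place of fluoro on an aromatic carbon. Within the data shown here, none of the measured steps exchanges one halogen for another; the two that reach compound 3 replace a whole aryl group, and even the larger of them, a 2.7-fold lower number from compound 2 to compound 3 (0.43 log units; beyond the scatter), is modest. Nothing here argues for a step beyond the scatter in either direction in this assay. Compound 4 is therefore expected to sit near the number of compound 3. The step expected is a 1.1-fold lower number from compound 3 to compound 4 (0.03 log units; within the scatter). The estimate for compound 4 is 7000 nM, with a range from 3000 nM to 16000 nM.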

Compound 4, half-maximal inhibitory concentration: 6680 nM
The estimate for compound 4 lay 1.0-fold (0.02 log units) above the measured number; low and high end bracket the measured number.
By their numbers in this assay, from the lowest: compounds 4, 3 and 1 (each within the scatter of the next); then compound 2.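

Among these compounds, exchanging fluoro for chloro on this aromatic carbon, ortho to a large group, is the first swap of one halogen for another, and in this assay it gives a 1.1-fold lower number from compound 3 to compound 4 (0.05 log units; within the scatter) and so no readable difference between the two halogens at this position. The 2-chlorophenyl group also cannot be told apart from the 4-methoxyphenyl group, with a 1.5-fold lower number from compound 1 to compound 4 (0.17 log units; within the scatter) as the step, whereas replacing the 4-(dimethylamino)phenyl group gives a 3.0-fold lower number from compound 2 to compound 4 (0.48 log units; beyond the scatter) and so a modest separation that a repeat measurement would not be expected to erase. No measurement at hand explains why fluoro and chloro read alike here.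

The compounds shown leave open whether this position tolerates only halogens or any small group, which a bromo, a methyl or a methoxy on the same carbon would help to settle. Going by these compounds, it also remains open whether an amine or a carboxylic acid on this aryl ring would shift the number beyond the scatter in either direction, or whether the same chloro on another carbon of the ring would read the same.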